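A few compounds are considered here, and "the series" means these few. Any claim that something is new, unique, unknown or untested is made for them only; others in the source may bear on it.

Within the data shown here, in a functional assay on MDA-MB-231 cells (Homo sapiens) for cytotoxicity, read by MTT assay, with a stated time of 72 h (on this read-out lower numbers stand for stronger inhibition and higher numbers for weaker inhibition), compound 1 (`O=C(CN1CCN(c2nnc(Cc3ccccc3)c3ccccc23)CC1)Nc1ccc(F)c(F)c1`) gives 2750 nM and compound 2 (`Cc1cccc(Cl)c1NC(=O)CN1CCN(c2nnc(Cc3ccccc3)c3ccccc23)CC1`) gives 3920 nM, so compound 2 stands within the scatter of the only other measured compound. That single measured step, a 1.4-fold higher number from compound 1 to compound 2 (0.15 log units; within the scatter), puts 2-chloro-6-methylphenyl in place of 3,4-difluorophenyl on an amide-type nitrogen. Compound 3 (`Cc1cccc(Cl)c1NC(=O)CN1CCN(c2nnc(Cc3ccncc3)c3ccccc23)CC1`) keeps that amide group and changes another place: pyridin-4-yl in place of phenyl on a saturated chain carbon bound to an aromatic carbon. It carries pyridin-4-yl in place of phenyl on a saturated chain carbon bound to an aromatic carbon. Among the measured compounds shown here, no measured step touches this place, so the data give no direct guide to its size or direction. No change beyond the scatter is therefore expected in this assay, and the estimated step is a 1.1-fold lower number from compound 2 to compound 3 (0.05 log units; within the scatter). Compound 3 is expected at 3500 nM, with an estimated range from 1300 nM to 9000 nM.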

Compound 3, half-maximal inhibitory concentration: 2670 nM
Estimate against measurement, compound 3: 1.3-fold (0.12 log units) above; measured number inside the range.
By their numbers in this assay, from the lowest: compounds 3, 1 and 2 (each within the scatter of the next).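

At the saturated chain carbon bound to an aromatic carbon, the step of a 1.5-fold lower number from compound 2 to compound 3 (0.17 log units; within the scatter) in this assay gives this place its first measured reading. Pyridin-4-yl, which brings one ring nitrogen and one hydrogen-bond acceptor that phenyl lacks, leaves the number within the scatter, so this single exchange does not separate the two rings in this assay. No supporting evidence is available to explain this result.

The compounds shown leave open whether pyridin-3-yl, pyridin-2-yl or a phenyl ring bearing an amine or a carboxylic acid would give a step beyond the scatter at this place. They also leave open whether pyridin-4-yl would give a similar step with 3,4-difluorophenyl on the amide-type nitrogen, or in another cell line.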